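From a sulfonamide to a urea on the shared core

A few compounds are considered here, and "the series" means these few. Any claim that something is new, unique, unknown or untested is made for them only; others in the source may bear on it.

Among the compounds with values here, compound 1 `Nc1ncnc2c1c(-c1nc3ccc(NS(=O)(=O)c4c(F)cccc4F)cc3[nH]1)cn2C1CCCC1` is the only member of this small set with a result: in an ADME assay on microsomes from liver (Rattus norvegicus) for metabolic stability (on this read-out higher numbers stand for higher hepatic extraction and lower numbers for lower hepatic extraction), compound 1 gives 0.69. Compound 2 `Nc1ncnc2c1c(C(=O)c1cccc(NS(=O)(=O)c3c(F)cccc3F)c1)cn2C1CCCC1` shares the aminopyrimidine-bearing core and the same (2,6-difluorophenyl)sulfonyl group, but in this assay compound 2 gives "not determined" (no result reported), so no single number stands for it, and nothing can be said of how compound 2 compares with compound 1 on this read-out.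

Compound 3 `Nc1ncnc2c1c(C(=O)c1cccc(NC(=O)Nc3ccc(Cl)cc3)c1)cn2C1CCCC1` differs from compound 2 in one place: (4-chlorophenyl)carbamoyl in place of (2,6-difluorophenyl)sulfonyl on a nitrogen on an aromatic ring. Within the data shown here, since compound 2 has no value, no measured step leads to compound 3, and the outcome for it can only be guessed from the single result of compound 1. The change is expected to move the read-out in this assay by no more than the usual scatter, in no clear direction, with the result for compound 3 most likely resembling that of compound 1.

Compound 3 is therefore estimated to give 0.65 in this assay, within a range from 0.4 to 0.85.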

Compound 3, hepatic extraction ratio: 0.7
The estimate for compound 3 lay 0.050 below the measured number; the range from low to high includes it.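

In this assay compound 3 gives 0.7, but no single number stands for compound 2, so the step from compound 2 to compound 3 cannot be read. The compounds shown leave open what putting (4-chlorophenyl)carbamoyl in place of (2,6-difluorophenyl)sulfonyl does to hepatic extraction. Nothing available bears on this result.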